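Chain length between core nitrogen and hydroxamic acid

The compounds below may be only part of what the source reports. "The series", "measured", "known", "first", "only" and "open" are said of these compounds alone.

Three compounds of the series have numbers in a functional assay on HCT-116 cells (Homo sapiens) for inhibition, read by MTT assay, with a stated time of 72 h; on this read-out higher numbers stand for weaker inhibition and lower numbers for stronger inhibition. Compound 1 `Nc1nc2cc(-c3nn(CCCC(=O)NO)c4ncnc(N)c34)ccc2o1` gives 19600 nM. Compound 2 `Nc1nc2cc(-c3nn(CCCCCCCCCC(=O)NO)c4ncnc(N)c34)ccc2o1` gives 23100 nM, the highest of the three, yet its nearest neighbour compound 1 and its furthest neighbour compound 3 both lie within the scatter of it. Compound 3 `Nc1ncnc2c1c(-c1cnc3[nH]ccc3c1)nn2CCCCCCCCCC(=O)NO` gives 18700 nM. Lengthening the chain, a 1.2-fold higher number from compound 1 to compound 2 (0.07 log units; within the scatter), and exchanging the aryl group on the core, a 1.2-fold lower number from compound 2 to compound 3 (0.09 log units; within the scatter), each moved the number by less than the usual scatter.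

Compound 4 `Nc1nc2cc(-c3nn(CCC(=O)NO)c4ncnc(N)c34)ccc2o1` is the next member. Against compound 2 the change is hydroxycarbamoyl in place of 7-(hydroxycarbamoyl)heptyl on a saturated chain carbon, two bonds along the chain from an aromatic nitrogen. Within the data shown here, the only measured step that bears on it is the chain change, a 1.2-fold higher number from compound 1 to compound 2 (0.07 log units; within the scatter), which ran in the opposite direction and stayed within the scatter. Nothing in the measured steps suggests that a shorter chain would move the number beyond the scatter either. The step is therefore expected to be small, a 1.1-fold lower number from compound 2 to compound 4 (0.02 log units; within the scatter), with no clear direction. Compound 4 is estimated to give 22000 nM in this assay, within a range of 10000 nM to 50000 nM.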

Compound 4, half-maximal inhibitory concentration: > 100000 nM
Compound 4: only a limit was reported; the forecaster's own chance of this, stated with the estimate: 10%; at least 4.5-fold (0.65 log units) between middle value and limit.
By their numbers in this assay, from the lowest: compounds 3, 1 and 2 (each within the scatter of the next). At a limit, above all of these: compound 4.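

In this assay compound 4 is reported only as a limit, > 100000 nM, and not as a number. Replacing the chain ending in hydroxycarbamoyl with the shorter one of compound 4 gives an at least 4.3-fold higher number from compound 2 to compound 4 (0.63 log units; beyond the scatter) and an at least 5.1-fold higher number from compound 1 to compound 4 (0.70 log units; beyond the scatter), so this position, where a 1.2-fold higher number from compound 1 to compound 2 (0.07 log units; within the scatter) had shown no change that could be told from the scatter, does respond to the chain at its short end, with the loss of a single (hydroxycarbamoyl)methyl unit already enough to go beyond the scatter. Both steps give only the smallest size the limit allows, and their true size stays unknown: the limit of > 100000 nM in this assay, at which 1 of the 4 values shown sits.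

As far as these compounds go, whether the short-chain loss carries over to the aryl group of compound 3 stays open, since the steps here are read only with the aryl group shared by compounds 1, 2 and 4. Also open, from the compounds shown here alone, is how the number responds to a chain longer than 7-(hydroxycarbamoyl)heptyl, or to a carboxylic acid or an amine in place of the hydroxycarbamoyl group at the end of the chain.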